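A Benzyl Group Added to the Amine of Compound 2

A few compounds are considered here, and "the series" means these few. Any claim that something is new, unique, unknown or untested is made for them only; others in the source may bear on it.

Of the compounds shown here, two of closely related build have been measured in an assay on membranes from brain for displacement of a labelled ligand from Sigma non-opioid intracellular receptor 1 (Cavia porcellus), read by scintillation counting, with a stated time of 120 min, in the presence of a further agent that is not named here; on this read-out higher numbers stand for weaker inhibition and lower numbers for stronger inhibition. For compound 1 `NCC1COCC(c2ccccc2)(c2ccccc2)O1` the reading in this assay is > 10000 nM, a limit of the assay rather than a number; this is the limit of > 10000 nM in this assay, at which 1 of the 2 values shown sits. For the measured compounds named here, compound 2 `NCC1COC(c2ccccc2)(c2ccccc2)CO1` gives in this assay 1400 nM, and this is the only actual number among the readings. Compound 2 therefore stands alone as the one measured point from which any expectation can be drawn.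

Compound 3 `c1ccc(CNCC2COC(c3ccccc3)(c3ccccc3)CO2)cc1` has not yet been measured. It differs from compound 2 by benzyl in place of hydrogen on an amine nitrogen. Going by the values given here, no measured pair shows a change of this kind, so the size of the step rests on expectation alone. The step from compound 2 to compound 3 in this assay is expected to be a 14-fold lower number from compound 2 to compound 3 (1.15 log units; beyond the scatter), a move toward stronger inhibition that goes beyond the usual scatter. For compound 3 the estimate in this assay is 100 nM, with a likely range from 20 nM to 500 nM.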

Compound 3, inhibition constant: 7.37 nM
Compound 3: the middle estimate sits 14-fold (1.13 log units) above what was measured; measured number below the stated range.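

For the compounds shown here, compound 3 gives the first measured step at this amine nitrogen in this assay: the change reads a 190-fold lower number from compound 2 to compound 3 (2.28 log units; beyond the scatter) and moves the result toward stronger inhibition. The position therefore accepts a benzyl group, with its six-membered aromatic ring of carbon, and the change in the reading is large rather than lost in the scatter. With the rest of the structure held the same, this single replacement of hydrogen on the nitrogen is enough to take the series from the modest reading of compound 2 to a far lower number.

Nothing among the data shown accounts for the size of this step, and the one limit in the set has no bearing on it. On these data alone, a single benzyl group is only one point at this nitrogen, so it remains open whether a methyl group, a longer phenethyl chain, a second benzyl group on the same nitrogen or a benzoyl group in place of the benzyl would keep, extend or lose the change.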